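Dimethylamino replaces hydroxy-nitro on the styryl arm

The compounds below may be only part of what the source reports. "The series", "measured", "known", "first", "only" and "open" are said of these compounds alone.

Measured compounds:
compound 1 `Cc1ccc(CS/C(=C/c2ccc(N(C)C)cc2)C(=O)c2ccc(Cl)cc2)cc1`, > 100000 nM
compound 2 `O=C(/C(=C\c1ccc(OCc2ccccc2)cc1)SCc1ccc(Cl)cc1)c1ccc(Cl)cc1`, 1000 nM
compound 3 `O=C(/C(=C\c1ccc(O)c([N+](=O)[O-])c1)SCc1ccc(Cl)cc1)c1ccc(Cl)cc1`, 10000 nM

In a functional assay on DU-145 cells (Homo sapiens) for inhibition, read by trypan blue exclusion, with a stated time of 96 h (a higher number here means a weaker inhibitor of growth, a lower number a stronger inhibitor of growth), compound 3 gives 10000 nM, the highest of the two numbers measured; the nearest is compound 2 at 1000 nM, a gap beyond the scatter. Compound 1 reaches only a limit in this assay, > 100000 nM, and (the limit of > 100000 nM in this assay, at which 1 of the 3 values shown sits).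

Compound 4 `CN(C)c1ccc(/C=C(/SCc2ccc(Cl)cc2)C(=O)c2ccc(Cl)cc2)cc1` has not been measured. It differs from compound 3 in one place: 4-(dimethylamino)phenyl in place of 4-hydroxy-3-nitrophenyl on a double-bonded chain carbon bound to a double-bonded chain carbon. Compound 1 also carries the 4-(dimethylamino)phenyl group, paired with a different benzyl group on the sulfur, and it sits at the limit of this assay. On that basis the step from compound 3 to compound 4 is expected to be upward, toward weaker growth inhibition, by a 4.0-fold higher number from compound 3 to compound 4 (0.60 log units; beyond the scatter), beyond the scatter. Compound 4 is therefore expected to give about 40000 nM in this assay, with a range from 8000 nM to 200000 nM, and a real chance that only a limit is reported.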

Compound 4, concentration for 50% growth inhibition: > 100000 nM
Compound 4 gave a limit, no number; the forecaster's own chance of this, stated with the estimate: 40%; middle value at least 2.5-fold (0.39 log units) from the limit.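

In this assay compound 4 gives > 100000 nM, which is a limit of the assay and not a number. With the benzyl group on the sulfur kept as in compound 3, replacing 4-hydroxy-3-nitrophenyl with 4-(dimethylamino)phenyl gives an at least 10-fold higher number from compound 3 to compound 4 (1.00 log units; beyond the scatter), so the limit reached by compound 1 also appears with the other benzyl group. Dimethylamino in place of benzyloxy on an aromatic carbon gives an at least 100-fold higher number from compound 2 to compound 4 (2.00 log units; beyond the scatter), which shows how much this group matters to growth inhibition.

From the compounds shown here alone, how far compound 4 lies past the limit stays unknown, and the step between compound 1 and compound 4, chloro in place of methyl, cannot be read: the limit of > 100000 nM in this assay, at which 2 of the 4 values shown sit. Going by these compounds, whether an amino or a methoxy group on that same aromatic carbon would stay close to compound 2 or also fall to the limit remains open.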